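A few compounds are considered here, and "the series" means these few. Any claim that something is new, unique, unknown or untested is made for them only; others in the source may bear on it.

Compound 1 `Oc1ccc(/C=N/NC(=S)Nc2ccccc2)cc1`: 242000 nM
Compound 2 `Cc1ccccc1NC(=S)N/N=C/c1ccc(O)cc1`: 36500 nM

For the measured compounds named here, in an assay for inhibition of ribonucleoside-diphosphate reductase RR1 (Homo sapiens), with a stated time of 30 min (a lower number here means a stronger inhibitor, a higher number a weaker inhibitor), compound 1 stands at the highest of the two numbers; the single measured step within this pair is a 6.6-fold lower number from compound 1 to compound 2 (0.82 log units; beyond the scatter). Compound 3 `Cc1ccc(NC(=S)N/N=C/c2ccc(O)cc2)cc1` differs from compound 1 by methyl in place of hydrogen on an aromatic carbon. Going by the values given here, the only step that bears on this change is a 6.6-fold lower number from compound 1 to compound 2 (0.82 log units; beyond the scatter), where the methyl enters at another place on the same ring, so a methyl para to a large group is expected to give a gain of smaller size. Compound 3 is therefore expected to show a 3.5-fold lower number from compound 1 to compound 3 (0.54 log units; beyond the scatter) in this assay. The estimate for compound 3 is 70000 nM, with a range from 20000 nM to 240000 nM.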

Compound 3, half-maximal inhibitory concentration: 14200 nM
Estimate against measurement, compound 3: 4.9-fold (0.69 log units) above; measured number outside the range, below it.
By their numbers in this assay, from the lowest: compound 3; then compound 2; then compound 1.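

Methyl in place of hydrogen, para to a large group, gives a 17-fold lower number from compound 1 to compound 3 (1.23 log units; beyond the scatter) in this assay and is a large step. The gain from methyl is therefore not confined to its place in compound 2 at 36500 nM and compound 3 at 14200 nM has the lowest number of the three compounds. No evidence accounts for this step.

From the compounds shown here alone, whether an ethyl, a methoxy or an amine in this same place would keep the gain remains open. So does whether a carboxylic acid there would reverse it.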